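The compounds below may be only part of what the source reports. "The series", "measured", "known", "first", "only" and "open" are said of these compounds alone.

Working notes on the series. Compound 1 `CCc1cccc2c(OC)c(-c3occ(C)c3C(=O)OC)ccc12` carries a methoxycarbonyl group on an aromatic carbon of the shared core; in a functional assay on KBVIN cells (Homo sapiens) for cytotoxicity, read by MTT assay, with a stated time of 72 h (on this read-out higher numbers stand for an effect only at larger amounts of compound and lower numbers for an effect already at smaller amounts), compound 1 gives 1.3 ug/mL. Compound 2 `CCCOC(=O)c1c(C)coc1-c1ccc2c(CC)cccc2c1OC` is the propyl ester. In this assay compound 2 gives > 10 ug/mL, which is a limit of the assay and not a number (the limit of > 10 ug/mL in this assay, at which 1 of the 3 values shown sits). Compound 3 `CCc1cccc2c(OC)c(-c3occ(C)c3CO)ccc12` has hydroxymethyl in place of methoxycarbonyl on an aromatic carbon, and in this assay compound 3 gives 6.6 ug/mL. Among the two numbers compound 3 stands highest, the nearest number lying one step away: a 5.1-fold higher number from compound 1 to compound 3 (0.71 log units; beyond the scatter). The other measured steps are an at least 7.6-fold higher number from compound 1 to compound 2 (0.88 log units; beyond the scatter) and an at least 1.5-fold lower number from compound 2 to compound 3 (0.18 log units; that floor lies within the scatter).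

Compound 4 `CCc1cccc2c(OC)c(-c3occ(C)c3COC)ccc12` differs from compound 3 by methyl in place of hydrogen on an oxygen on a saturated carbon, that is, hydroxy to methoxy, hydroxymethyl to methoxymethyl. The step that bears most on it is an at least 7.6-fold higher number from compound 1 to compound 2 (0.88 log units; beyond the scatter), where adding carbon at the same region of the molecule raised the number; an at least 1.5-fold lower number from compound 2 to compound 3 (0.18 log units; that floor lies within the scatter) adds little, its floor sitting within the scatter. For compound 4 a small rise in the number is therefore expected, a 1.4-fold higher number from compound 3 to compound 4 (0.13 log units; within the scatter), likely not beyond the scatter. The estimate for compound 4 in this assay is 9 ug/mL, with a range from 4 ug/mL to 20 ug/mL.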

Compound 4, concentration for half-maximal effect: 8.8 ug/mL
Compound 4: the middle estimate sits 1.0-fold (0.01 log units) above what was measured; the range from low to high includes it.
By their numbers in this assay, from the lowest: compound 1; then compounds 3 and 4 (each within the scatter of the next). At a limit, above all of these: compound 2.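

In this assay methyl in place of hydrogen on an oxygen on a saturated carbon gives a 1.3-fold higher number from compound 3 to compound 4 (0.12 log units; within the scatter), a step that cannot be told from the scatter. The free hydroxy of the hydroxymethyl group therefore does not set the reading of this pair, and methoxymethyl in place of the methoxycarbonyl group gives a 6.8-fold higher number from compound 1 to compound 4 (0.83 log units; beyond the scatter), a step beyond the scatter that resembles a 5.1-fold higher number from compound 1 to compound 3 (0.71 log units; beyond the scatter), so among the compounds with numbers the methyl ester alone stands apart from both non-carbonyl groups. Methoxymethyl in place of propoxycarbonyl gives an at least 1.1-fold lower number from compound 2 to compound 4 (0.05 log units; that floor lies within the scatter), which cannot be read as a difference, since compound 2 stands at a limit and not at a number: the limit of > 10 ug/mL in this assay, at which 1 of the 4 values shown sits.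

Open, on these data alone, is how a group of another kind at this place would read, such as an aminomethyl group or a free carboxylic acid, and whether a longer ether chain such as propoxymethyl would stay level with methoxymethyl. Also open, as far as these compounds go, is whether an ethyl ester would fall nearer compound 1 or compound 2, which would show how quickly the ester chain can grow before the number rises.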